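Swapping Bromo for Iodo at an Assay Limit

The compounds below may be only part of what the source reports. "The series", "measured", "known", "first", "only" and "open" are said of these compounds alone.

In a functional assay on MCF7 cells (Homo sapiens) for inhibition (a higher number here means a weaker inhibitor, a lower number a stronger inhibitor), compound 2 `Cc1ccc2nc(-c3ccc(N)cc3Br)sc2c1` gives < 0.1 nM, which is a limit and not a number. Compound 1 `Nc1ccc(-c2nc3ccccc3s2)c(Br)c1` gives < 0.1 nM, also a limit. Compound 3 `Nc1cc(Br)c(-c2nc3ccccc3o2)c(Br)c1` gives < 10 nM, again a limit. Compound 4 `Cc1ccc2nc(-c3ccc(N)cc3I)sc2c1` differs from compound 2 by iodo in place of bromo on an aromatic carbon. Within the data shown here, the only measured step is a step that the two limits leave unreadable from compound 1 to compound 2, and it is a different change, so it offers no size to carry over. No step beyond the scatter is therefore expected in this assay, in either direction. The expected change is a step that the limit leaves unreadable from compound 2 to compound 4. For compound 4, the estimate is 0.05 nM, with an expected range from 0.005 nM to 0.5 nM.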

Compound 4, half-maximal inhibitory concentration: < 0.1 nM
Compound 4 was reported as a limit (the forecaster's own chance of this, stated with the estimate: 70%); the middle value lies beyond the limit too.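

Compound 2 and compound 4 are both reported only as limits in this assay, and no step can be read between them. The compounds shown leave open whether iodo and bromo differ in strength here at all.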